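Phenylsulfanyl replacing pyrazolyl on the shared core

The source may report more compounds than this note shows. Statements on the series, on what has been measured and on what is new or still open speak of the compounds shown alone.

For the measured compounds named here, compound 3, `Cc1nn(C)c(-n2cccn2)c1/C=N/OCc1ccc(C(=O)OC(C)(C)C)cc1`, stands highest of the three numbers so far in a functional assay on XF498 cells (Homo sapiens) for cytotoxicity (a higher number here means a weaker inhibitor, a lower number a stronger inhibitor), with 5.51 ug/mL. Compound 1, `Cc1nn(C)c(-n2cccc2)c1/C=N/OCc1ccc(C(=O)OC(C)(C)C)cc1`, gives 2.67 ug/mL in this assay, and compound 2, `Cc1nn(C)c(Oc2ccc(Cl)cc2)c1/C=N/OCc1ccc(C(=O)OC(C)(C)C)cc1`, gives 0.02 ug/mL. The change from compound 1 to compound 3 was small, a 2.1-fold higher number from compound 1 to compound 3 (0.31 log units; beyond the scatter), whereas the change from compound 2 to compound 3 was large, a 280-fold higher number from compound 2 to compound 3 (2.44 log units; beyond the scatter), as was a 130-fold lower number from compound 1 to compound 2 (2.13 log units; beyond the scatter).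

Compound 4, `Cc1nn(C)c(Sc2ccccc2)c1/C=N/OCc1ccc(C(=O)OC(C)(C)C)cc1`, differs from compound 3 in one place: phenylsulfanyl in place of 1H-pyrazol-1-yl on an aromatic carbon. Going by the values given here, the step that bears most directly on this is the one from compound 2 to compound 3, in which a six-membered carbon ring attached through a single hetero atom gave way to a five-membered aromatic ring with 2 hetero atoms attached directly, and the number rose by a large amount. Compound 4 returns to an arrangement of that first kind, with a six-membered aromatic ring of carbon only attached through one sulfur. Among the compounds with values here, both five-membered azoles, compound 1 and compound 3, sit at the weak end, and no measured compound goes against this picture. Within the data shown here, a large step down in this assay is therefore expected, a 92-fold lower number from compound 3 to compound 4 (1.96 log units; beyond the scatter), though the sulfur linkage has no precedent here, so the range is kept wide. Compound 4 is estimated at 0.06 ug/mL, within 0.01 ug/mL to 0.6 ug/mL.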

Compound 4, half-maximal inhibitory concentration: 0.28 ug/mL
Compound 4: the middle estimate sits 4.7-fold (0.67 log units) below what was measured; the measured number falls inside the stated range.
By their numbers in this assay, from the lowest: compound 2; then compound 4; then compound 1; then compound 3.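

In this assay, a six-membered aromatic ring of carbon only, attached through one hetero atom, now stands ahead of the azoles with a second linking atom as well: phenylsulfanyl gives a 20-fold lower number from compound 3 to compound 4 (1.29 log units; beyond the scatter), and a 9.5-fold lower number from compound 1 to compound 4 (0.98 log units; beyond the scatter). The linking atom and the ring substituent still matter at this position, since the exchange of 4-chlorophenoxy for phenylsulfanyl gives a 14-fold higher number from compound 2 to compound 4 (1.15 log units; beyond the scatter), so an aryl group on a single hetero atom does not by itself reach the lowest number in the series. No measurement available here accounts for any of these steps.

That last step changes the linking atom and removes the chlorine at once, so its size cannot be divided between the two changes; the unsubstituted phenoxy group and the 4-chlorophenylsulfanyl group would separate them. Also open, on these data alone, is whether a nitrogen link, as in an anilino group, or a methylene link, as in a benzyl group, would keep the aryl group ahead of the azoles at this position.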